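Removing a Fluorine: From Compound 3 to Compound 4

A few compounds are considered here, and "the series" means these few. Any claim that something is new, unique, unknown or untested is made for them only; others in the source may bear on it.

Measured so far:
- compound 1, `CC(C(=O)N1CCN(c2ccc(Cl)cc2)CC1)N1C(=O)CCC1=O`, gives 0%
- compound 2, `CC(C(=O)N1CCN(c2ccccc2F)CC1)N1C(=O)CCC1=O`, gives 0%
- compound 3, `CCC(C(=O)N1CCN(c2ccccc2F)CC1)N1C(=O)CCC1=O`, gives 0%

All three were tested in a functional assay on the whole organism (strain Swiss) with Mus musculus as the target, in the maximal electroshock model, with a stated time of 1 h, at a dose of 100 mg/kg by the intraperitoneal route; on this read-out lower numbers stand for a weaker effect and higher numbers for a stronger effect at the one dose given. Compound 3 stands level with compound 1 and compound 2 at the digits shown: the change from a 4-chlorophenyl to a 2-fluorophenyl group brought no change at the digits printed from compound 1 to compound 2 (within the scatter), and adding a methyl on the chain brought no change at the digits printed from compound 2 to compound 3 (within the scatter). None of the three shows any effect in this assay .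

Compound 4, `CCC(C(=O)N1CCN(c2ccccc2)CC1)N1C(=O)CCC1=O`, differs from compound 3 in one place: hydrogen in place of fluoro on an aromatic carbon. Among the compounds with values here, no measured step swaps fluoro for hydrogen on the aromatic ring, so the closest guide is the change of ring substituent between compound 1 and compound 2, which stayed within the scatter. Within the data shown here, because compound 3 gives 0% and the earlier steps brought no change at the digits printed from compound 1 to compound 2 (within the scatter) and no change at the digits printed from compound 2 to compound 3 (within the scatter), compound 4 is expected to show no change at the digits printed from compound 3 to compound 4 (within the scatter). The estimate for compound 4 in this assay is therefore 0%, with a range from 0% to 10%.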

Compound 4, a percentage reported as activity, at one dose (the size of the read-out at that dose, not a potency): 0%
Compound 4: the middle estimate sits on the measured number at the digits printed; the measured number falls inside the stated range.
By their numbers in this assay, from the lowest: compounds 1, 2, 3 and 4 (each within the scatter of the next).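

Replacing the 2-fluorophenyl with a plain phenyl in this assay brought no change at the digits printed from compound 3 to compound 4 (within the scatter). This adds a ring with no substituent at all to the halogen-bearing rings seen so far, and compound 4 still gives 0%, which shows that removing the fluoro from this aromatic carbon does not bring out an effect at this one dose, while a read-out at zero has no room to fall and cannot show whether the fluoro contributes anything. No evidence is available that explains this result.

The compounds shown leave open whether any other group on this ring, such as a methoxy or a trifluoromethyl, would give a read-out above zero. They also leave open whether a longer chain in place of the methyl added in compound 3 would do so.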